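This account rests on a few compounds, and the source may have more. Where it says the series, first, only, none or still open, it means among the compounds named here.

Compound 1 `Oc1ccc(CNc2cc(C(F)(F)F)cc3[nH]ncc23)cc1` was tested in an assay for inhibition of Tryptophan 2,3-dioxygenase (Homo sapiens), with stated times of 10 min and 60 min, tested at 10 uM (a lower number here means a weaker effect, a higher number a stronger effect of the compound at the concentration tested), where compound 1 gives 75%. Going by the values given here, that is the lower of the two numbers known here: compound 2 `Oc1ccc(CNc2cc(C(F)(F)F)cc3[nH]ncc23)c(Cl)c1` gives 92% in this assay, and the single measured step between them, a number 17 percentage points higher from compound 1 to compound 2 (beyond the scatter), comes from a chloro in place of hydrogen on an aromatic carbon. Compound 3 `FC(F)(F)c1cc(NCC2CNC2)c2cn[nH]c2c1` has not yet been measured; it differs from compound 1 by azetidin-3-yl in place of 4-hydroxyphenyl on a saturated chain carbon bound to a nitrogen on an aromatic ring. Among the compounds with values here, no measured step swaps the 4-hydroxyphenyl for anything else, so the one known step bears only loosely on this change: it shows that altering that part of compound 1 can move the number, but it gives no direction for removing the ring altogether. The expectation for compound 3 must therefore be wide and is placed somewhat lower. Compound 3 is estimated at 45% in this assay, with a range from 10% to 80%, meaning an expected step of a number 30 percentage points lower from compound 1 to compound 3 (beyond the scatter).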

Compound 3, a percentage reported as inhibition, at one concentration (the size of the read-out at that concentration, not a potency): 5%
Beside the measured number, compound 3's estimate is 40 percentage points above it; the whole stated range lies above it.
By their numbers in this assay, from the lowest: compound 3; then compound 1; then compound 2.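

Replacing the 4-hydroxyphenyl with azetidin-3-yl on the saturated chain carbon gives a number 70 percentage points lower from compound 1 to compound 3 (beyond the scatter) in this assay, far larger than the modest step seen earlier with the chloro. The earlier compounds shown here showed only that a small addition to this aromatic ring can raise the number, whereas this result shows that the number depends heavily on which group occupies this place, even though the shared core is unchanged and the two groups have matching counts of hydrogen-bond donors and acceptors. No measurement here accounts for the drop.

On these data alone, it remains open whether the aromatic ring, the hydroxyl or the size of the group matters most. A plain phenyl or a piperidin-4-yl at this place would help separate these possibilities.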